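A few compounds are considered here, and "the series" means these few. Any claim that something is new, unique, unknown or untested is made for them only; others in the source may bear on it.

Measured in a functional assay on MCF7 cells (Homo sapiens) for inhibition, read by MTT assay, with a stated time of 48 h; on this read-out lower numbers stand for stronger inhibition and higher numbers for weaker inhibition:

compound 1 `CCOC(=O)C1=C(N/C=N/c2cccnc2Cl)Nc2[nH]nc(C)c2C1c1ccc(N(C)C)cc1`: 4180 nM
compound 2 `CCOC(=O)C1=C(N/N=C(/Cl)c2ccc([N+](=O)[O-])cc2)Nc2[nH]nc(C)c2C1c1ccc(N(C)C)cc1`: 52700 nM
compound 3 `CCOC(=O)C(=NNC1=C(C(=O)OCC)C(c2ccc(N(C)C)cc2)c2c(C)n[nH]c2N1)C(=O)OCC`: 89800 nM

Compound 3 stands level with compound 2 (a 1.7-fold higher number from compound 2 to compound 3 (0.23 log units; within the scatter)) and well apart from compound 1 (a 21-fold higher number from compound 1 to compound 3 (1.33 log units; beyond the scatter)). Compound 4 `CCOC(=O)C1=C(N/C=N/c2ccc(C)cc2)Nc2[nH]nc(C)c2C1c1ccc(N(C)C)cc1` differs from compound 3 by a group of 9 heavy atoms (8 carbon, 1 nitrogen; one six-membered aromatic ring of carbon only) in place of a group of 12 heavy atoms (7 carbon, 1 nitrogen, 4 oxygen; no ring), on an amine nitrogen. The entering group has 9 heavy atoms, as does the group in compound 1, though compound 1 has one six-membered aromatic ring with 1 hetero atom and compound 4 has one six-membered aromatic ring of carbon only. The closest guide is therefore the step to compound 3 from compound 1 (a 21-fold higher number from compound 1 to compound 3 (1.33 log units; beyond the scatter)), read in reverse. Compound 2 cautions that an aromatic ring alone does not bring a low number (a 13-fold higher number from compound 1 to compound 2 (1.10 log units; beyond the scatter)). A large step toward a lower number is thus expected in this assay, somewhat short of the full gap to compound 1. The estimate is a 15-fold lower number from compound 3 to compound 4 (1.18 log units; beyond the scatter) (an expected value, not a measured one). Compound 4 is expected at 6000 nM (estimated range 1800 nM to 20000 nM).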

Compound 4, half-maximal inhibitory concentration: 50500 nM
The estimate for compound 4 lay 8.4-fold (0.93 log units) below the measured number; measured number above the stated range.
By their numbers in this assay, from the lowest: compound 1; then compounds 4, 2 and 3 (each within the scatter of the next).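

In this assay the exchange of 2-chloropyridin-3-yl for 4-methylphenyl on the double-bonded nitrogen, with the rest of the molecule unchanged, gives a 12-fold higher number from compound 1 to compound 4 (1.08 log units; beyond the scatter) and so ties the low number of compound 1 to that ring rather than to the linker the two compounds share. The carbon-only ring of compound 4 does not set it apart from the open-chain group, with a 1.8-fold lower number from compound 3 to compound 4 (0.25 log units; within the scatter) within the scatter, or from the chlorinated nitrophenyl-bearing group, with a 1.0-fold lower number from compound 2 to compound 4 (0.02 log units; within the scatter) also within the scatter, so among these four compounds only compound 1 stands apart. Nothing available bears on why this ring exchange has so large an effect.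

The 2-chloropyridin-3-yl group differs from 4-methylphenyl in both its ring nitrogen and its chlorine, so the compounds shown do not tell which of the two goes with the low number. A pyridine ring without chlorine, or a phenyl ring carrying chlorine, would separate them.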